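Ethoxy in Place of Methyl on Compound 3

This account rests on a few compounds, and the source may have more. Where it says the series, first, only, none or still open, it means among the compounds named here.

In a functional assay on MOLT-4 cells (Homo sapiens) for antiproliferative activity (a lower number here means a stronger inhibitor, a higher number a weaker inhibitor), compound 3 `COc1cc(C(=O)c2sc(-c3ccc(C)cc3)cc2N)cc(OC)c1OC` gives 16 nM as its half-maximal inhibitory concentration. Compound 2 `COc1cc(C(=O)c2sc(-c3ccsc3)cc2N)cc(OC)c1OC` gives 8.8 nM in the same test. The move between these two is a 1.8-fold higher number from compound 2 to compound 3 (0.26 log units; within the scatter) and so they stand level.

Compound 1 `COc1cc(C(=O)c2sc(-c3ccc(-c4ccccc4)cc3)cc2N)cc(OC)c1OC` gives > 10000 nM which is a limit and not a number. Putting methyl in place of its phenyl is an at least 620-fold lower number from compound 1 to compound 3 (2.79 log units; beyond the scatter) and this is a very large step.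

Compound 4 `CCOc1ccc(-c2cc(N)c(C(=O)c3cc(OC)c(OC)c(OC)c3)s2)cc1` has ethoxy in place of methyl on an aromatic carbon, para to a large group ethoxy in place of methyl on an aromatic carbon and this turns 4-methylphenyl to 4-ethoxyphenyl. The change falls on the same carbon as the large step, so that step is the main warning: what sits there can matter greatly. The step to compound 3 from compound 2 offers some comfort, since replacing a whole thiophen-3-yl group left the number within the scatter. Within the data shown here, no measured step covers ethoxy itself, so the margin must stay wide, especially on the weaker side.

The expected step in this assay is a 1.1-fold lower number from compound 3 to compound 4 (0.06 log units; within the scatter) with no clear direction beyond the scatter. For compound 4 the estimated value is 14 nM with an expected range from 3 nM to 80 nM in this test.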

Compound 4, half-maximal inhibitory concentration: 240 nM
The estimate for compound 4 lay 17-fold (1.23 log units) below the measured number; the measured number lies above the stated range.
By their numbers in this assay, from the lowest: compounds 2 and 3 (each within the scatter of the next); then compound 4. At a limit, above all of these: compound 1.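

In this assay, among these compounds, this carbon proves far less forgiving than the earlier compounds suggested: methyl, with 1 heavy atom, gives way to ethoxy, with 3 heavy atoms, and the result is a 15-fold higher number from compound 3 to compound 4 (1.18 log units; beyond the scatter). The swap of whole groups tells the same story, with a 27-fold higher number from compound 2 to compound 4 (1.44 log units; beyond the scatter), even though the two compounds at the start of that step and of the step before it, compounds 2 and 3, stand level, so the room for change seen there does not reach every group at this place. Ethoxy in place of phenyl still gives an at least 41-fold lower number from compound 1 to compound 4 (1.61 log units; beyond the scatter), which shows that activity here is not simply kept or lost, although this step starts from a limit and not a number: the limit of > 10000 nM in this assay, at which 1 of the 4 values shown sits.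

As far as these compounds go, it remains open whether the oxygen or the length of the group goes with the higher number for compound 4, and methoxy or a plain ethyl or propyl chain at this carbon would separate the two. How a hydroxyl group or an amine would behave here also remains unknown, and these values alone give no cause for the step.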